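This account rests on a few compounds, and the source may have more. Where it says the series, first, only, none or still open, it means among the compounds named here.

For the measured compounds named here, compound 2 `Cn1cc(NC(=O)c2cnc3ccc(N[C@@H]4CCCNC4)nn23)c(C(F)(F)F)n1` holds the higher of the two numbers measured so far in a functional assay on TMD8 cells (Homo sapiens) for cytotoxicity, read by CCK-8 assay, with a stated time of 72 h (a higher number here means a weaker inhibitor, a lower number a stronger inhibitor), where compound 2 gives 5900 nM. Its nearest neighbour is compound 1 `Cn1cc(NC(=O)c2cnc3ccc(N[C@@H]4CCCNC4)nn23)c(C(F)F)n1`, which in this assay gives 1200 nM. Going by the values given here, the single measured step, a 4.9-fold higher number from compound 1 to compound 2 (0.69 log units; beyond the scatter), is fluoro in place of hydrogen on a saturated chain carbon bound to an aromatic carbon and two fluorine atoms. Compound 3 `Cn1cc(NC(=O)c2cnc3ccc(N[C@@H]4CCCNC4)nn23)c(C#N)n1` differs from compound 2 by cyano in place of trifluoromethyl on an aromatic carbon. Among the compounds with values here, no measured step exchanges trifluoromethyl for cyano, so the step from compound 1 to compound 2 bears only indirectly: it shows that altering the group at this aromatic carbon moved the number beyond the scatter. Compound 3 is therefore expected to give a lower number than compound 2, an estimated step of a 3.0-fold lower number from compound 2 to compound 3 (0.47 log units; beyond the scatter). The estimate for compound 3 is 2000 nM, with a range from 700 nM to 6000 nM.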

Compound 3, half-maximal inhibitory concentration: 14800 nM
The estimate for compound 3 lay 7.4-fold (0.87 log units) below the measured number, and the stated range ends below it.
By their numbers in this assay, from the lowest: compound 1; then compound 2; then compound 3.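

Replacing trifluoromethyl with cyano on this aromatic carbon weakens the compound further in this assay, with a 2.5-fold higher number from compound 2 to compound 3 (0.40 log units; beyond the scatter), so the group with fewer heavy atoms does not restore the number. Against difluoromethyl the same exchange is larger, with a 12-fold higher number from compound 1 to compound 3 (1.09 log units; beyond the scatter), making this the widest step among the three compounds and leaving difluoromethyl with the lowest number of the three groups at this carbon. Nothing measured here accounts for this order of the groups.

As far as these compounds go, whether a methyl, a chlorine atom or an amine at this carbon would fall below or above difluoromethyl remains open. So does whether the same order of groups would hold with a different amine in place of the saturated ring on the shared core.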